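Adding a methyl to the phenyl ring of compound 3

The compounds below may be only part of what the source reports. "The series", "measured", "known", "first", "only" and "open" are said of these compounds alone.

Of the compounds shown here, three sharing one core have been measured so far in a functional assay on OVCAR-3 cells (Homo sapiens) for inhibition, read by MTT assay, with a stated time of 24 h (a higher number here means a weaker inhibitor, a lower number a stronger inhibitor), and differ only on a phenyl ring. Compound 3 `CC1(C)[C@H]2CC[C@]1(C)N(Cc1cn(-c3ccccc3)nn1)C(=O)C2` has a bare phenyl ring and gives 50 nM as the lowest number of the three, which makes it the strongest inhibitor here. Compound 1 `CC1(C)[C@H]2CC[C@]1(C)N(Cc1cn(-c3ccccc3Br)nn1)C(=O)C2` has bromo on that ring and gives 140 nM while compound 2 `CC1(C)[C@H]2CC[C@]1(C)N(Cc1cn(-c3ccccc3F)nn1)C(=O)C2` has fluoro there and gives 300 nM as the highest number.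

The next compound, compound 4 `Cc1ccc(-n2cc(CN3C(=O)C[C@@H]4CC[C@@]3(C)C4(C)C)nn2)cc1`, changes phenyl to 4-methylphenyl, with methyl in place of hydrogen on an aromatic carbon as the counted difference: methyl in place of hydrogen on an aromatic carbon, para to a large group.

Within the data shown here, two measured steps bear most directly on this. Taking a halogen off the ring gave a 2.8-fold lower number from compound 1 to compound 3 (0.45 log units; beyond the scatter) for bromo and a 6.0-fold lower number from compound 2 to compound 3 (0.78 log units; beyond the scatter) for fluoro, so the ring without an added group had the lower number both times. The two halogens also differ from each other, with a 2.1-fold higher number from compound 1 to compound 2 (0.33 log units; beyond the scatter) separating them. Among the measured compounds shown here, no measured compound carries a methyl, so this evidence is indirect.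

In this assay a modest rise in the number is therefore expected. The estimated change is a 2.0-fold higher number from compound 3 to compound 4 (0.30 log units; within the scatter) and would be a modest weakening. Compound 4 is estimated at 100 nM with an expected range of 35 nM to 300 nM overall.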

Compound 4, half-maximal inhibitory concentration: 40 nM
Compound 4: middle estimate off by 2.5-fold (0.40 log units), on the high side; the range from low to high includes it.
By their numbers in this assay, from the lowest: compounds 4 and 3 (each within the scatter of the next); then compound 1; then compound 2.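

In this assay, methyl in place of hydrogen on this aromatic carbon, para to a large group, gives a 1.3-fold lower number from compound 3 to compound 4 (0.10 log units; within the scatter), so compounds 3 and 4 cannot be told apart and this position accepts a methyl with no measurable loss. The earlier compounds shown here showed only halogen-bearing rings with higher numbers than the bare ring, whereas the 4-methylphenyl ring shows that a group on the phenyl ring need not raise the number: the steps are a 3.5-fold lower number from compound 1 to compound 4 (0.54 log units; beyond the scatter) and a 7.5-fold lower number from compound 2 to compound 4 (0.88 log units; beyond the scatter), both beyond the scatter. Compounds 1 and 2 still go against any broader rule, and these two steps change both the group and its place on the ring, so they cannot separate the two effects, and nothing shown here explains the result.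

Going by these compounds, it remains open whether a longer chain such as propyl, or a group of another kind such as an amine or a carboxylic acid, would fit this position as well as methyl does. On these data alone, it is also open whether bromo or fluoro would behave like methyl here, and whether methyl would behave like those halogens at the place they occupy in compounds 1 and 2.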